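Naphthalenyl for Formylphenyl on a Benzyl-Bearing Core

The source may report more compounds than this note shows. Statements on the series, on what has been measured and on what is new or still open speak of the compounds shown alone.

Compound 1 `O=Cc1ccc(-c2cn3ccnc3c(-c3ccc4ncn(C5CCCCC5)c4c3)n2)cc1` is the reference point of this small set. In a functional assay on MDA-MB-231 cells (Homo sapiens) for inhibition, read by sulforhodamine B assay, with a stated time of 48 h, tested at 10 uM (on this read-out lower numbers stand for less inhibition and higher numbers for more inhibition at the one concentration tested (going by the name of the read-out)), compound 1 gives 51.2%. Compound 2 `c1ccc2c(-c3cn4ccnc4c(-c4ccc5ncn(C6CCCCC6)c5c4)n3)cccc2c1` carries the change (naphthalen-1-yl in place of 4-formylphenyl on an aromatic carbon), and in this assay compound 2 gives 20.8%, a step of a number 30.4 percentage points lower from compound 1 to compound 2 (beyond the scatter). Compound 3 `O=Cc1ccc(-c2cn3ccnc3c(-c3ccc4ncn(Cc5ccccc5)c4c3)n2)cc1` differs from compound 1 by benzyl in place of cyclohexyl on an aromatic nitrogen; in this assay compound 3 gives 51.2%, which is no change at the digits printed from compound 1 to compound 3 (within the scatter).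

Compound 4 `c1ccc(Cn2cnc3ccc(-c4nc(-c5cccc6ccccc56)cn5ccnc45)cc32)cc1` has not yet been measured in this assay. It differs from compound 3 by naphthalen-1-yl in place of 4-formylphenyl on an aromatic carbon. This is the same change as the one from compound 1 to compound 2, with the place described in identical words, and it occurs twice among these four compounds; the two cores differ by benzyl in place of cyclohexyl on an aromatic nitrogen. Because the step of a number 30.4 percentage points lower from compound 1 to compound 2 (beyond the scatter) was large and the core change no change at the digits printed from compound 1 to compound 3 (within the scatter) did not move the read-out, the step from compound 3 to compound 4 is expected to be about a number 30.2 percentage points lower from compound 3 to compound 4 (beyond the scatter). Compound 4 is therefore estimated at 21% in this assay, with a likely range from 5% to 40%.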

Compound 4, a percentage reported as inhibition, at one concentration (the size of the read-out at that concentration, not a potency): 28.7%
Compound 4: middle estimate off by 7.7 percentage points, on the low side; the measured number falls inside the stated range.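

In this assay, naphthalen-1-yl in place of 4-formylphenyl on the benzyl-bearing core comes with a number 22.5 percentage points lower from compound 3 to compound 4 (beyond the scatter), so the loss seen on the cyclohexyl-bearing core carries over to the second core: the same change on two cores in this assay, a number 30.4 percentage points lower (beyond the scatter) from compound 1 to compound 2 and a number 22.5 percentage points lower (beyond the scatter) from compound 3 to compound 4, 7.9 percentage points apart, within the scatter of two such steps Read the other way, benzyl in place of cyclohexyl with naphthalen-1-yl present comes with a number 7.9 percentage points higher from compound 2 to compound 4 (within the scatter), which matches the lack of a step seen with 4-formylphenyl present: the same change on two cores in this assay, no change at the digits printed (within the scatter) from compound 1 to compound 3 and a number 7.9 percentage points higher (within the scatter) from compound 2 to compound 4, 7.9 percentage points apart, within the scatter of two such steps This shows that the two changes behaved independently across these four compounds at the one concentration tested, but it does not show that the step would hold on any other core, or say why it occurs.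

The compounds shown leave open whether the step follows the loss of the formyl group or the arrival of the second aromatic ring of naphthalen-1-yl. A plain phenyl, or a phenyl bearing a carboxylic acid or an amine in place of the formyl group, would bear on that question, and a longer chain on the aromatic nitrogen would test the core side.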